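Swapping Cyano for Chloro on the Aniline Ring

The compounds below may be only part of what the source reports. "The series", "measured", "known", "first", "only" and "open" are said of these compounds alone.

Measured so far:
- Compound 1, `O=C([C@@H]1C[C@H](Nc2ccccc2)CN1)N1CCSC1`, in an assay on a cell-free system (plasma) for inhibition of Dipeptidyl peptidase 4 (Rattus norvegicus), read by fluorescence (on this read-out higher numbers stand for weaker inhibition and lower numbers for stronger inhibition), gives 190 nM.
- Compound 2, `N#Cc1ccc(N[C@@H]2CN[C@H](C(=O)N3CCSC3)C2)cc1`, in this assay gives 33.6 nM.

Within the data shown here, compound 2 stands at the lower of the two numbers, and its only neighbour is compound 1, which shows the higher one. Among the measured compounds shown here, the single step so far, a 5.7-fold lower number from compound 1 to compound 2 (0.75 log units; beyond the scatter), came from adding a cyano group to the phenyl ring of the shared core, and it lies beyond the scatter.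

Compound 3, `O=C([C@@H]1C[C@H](Nc2ccc(Cl)cc2)CN1)N1CCSC1`, carries a different group at the same spot: chloro in place of cyano on an aromatic carbon. For the measured compounds named here, no measured step shows a cyano-to-chloro swap directly; the one available step only tells that putting cyano in place of hydrogen on this ring lowered the number. Chloro is another substituent at that carbon, so compound 3 is expected to stay closer to compound 2 than to compound 1, with a small step upward or none beyond the scatter.

The estimated step is a 1.6-fold higher number from compound 2 to compound 3 (0.21 log units; within the scatter). For compound 3 the expected value in this assay is 55 nM, within a range of 20 nM to 150 nM.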

Compound 3, half-maximal inhibitory concentration: 55.1 nM
Compound 3: middle estimate off by 1.0-fold (0.00 log units), on the low side, within the range that was stated.
By their numbers in this assay, from the lowest: compounds 2 and 3 (each within the scatter of the next); then compound 1.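

In this assay, the lower number at this aromatic carbon, para to a large group, is no longer tied to cyano alone: a 3.4-fold lower number from compound 1 to compound 3 (0.54 log units; beyond the scatter) lies beyond the scatter, so chloro in place of hydrogen also lowers the number. Meanwhile, a 1.6-fold higher number from compound 2 to compound 3 (0.21 log units; within the scatter) stays within the scatter, so this assay does not separate chloro from cyano, even though the two groups differ in what is counted: chloro is a single chlorine atom with no hydrogen-bond acceptor, while cyano has two heavy atoms, a triple bond and one hydrogen-bond acceptor. Nothing at hand explains why these two different groups give values within the scatter of each other.

As far as these compounds go, with only two substituents compared against hydrogen at this carbon, it remains open whether the lower number follows from almost any group placed there or only from some kinds of group. A methyl, a methoxy or an amine at the same carbon would test that, and fluoro or bromo would show whether chloro's neighbours among the halogens give a similar value.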